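Swapping phenyl for methylpyrazole on an anilinonitrile scaffold

The source may hold more compounds than are shown below. What is called first, only, known or untested is meant among the compounds shown, and "the series" means these compounds.

Compound 1 `CCN(c1ccc(C#N)c(Cl)c1)c1cc(-c2ccccc2)ccc1C`. In a functional assay on CWR22R cells (Homo sapiens) for antiproliferative activity, read by CCK-8 assay, with a stated time of 6 days (on this read-out higher numbers stand for weaker inhibition and lower numbers for stronger inhibition), compound 1 gives > 30000 nM, which is a limit of the assay rather than a number.
Compound 2 `Cc1noc(C)c1-c1cccc2c1CCCN2c1ccc(C#N)c(C(F)(F)F)c1`. In this assay compound 2 is recorded as "not determined" (no result reported).
Compound 3 `Cn1nccc1-c1cccc2c1CCCN2c1ccc(C#N)c(C(F)(F)F)c1`. In this assay compound 3 gives 10400 nM.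

Going by these compounds, compound 1 therefore stands at the limit of > 30000 nM in this assay, at which 1 of the 3 values shown sits, so its true value is unknown beyond that bound. Compound 4 `CCN(c1ccc(C#N)c(Cl)c1)c1cc(-c2ccnn2C)ccc1C` differs from compound 1 in one place: 1-methyl-1H-pyrazol-5-yl in place of phenyl on an aromatic carbon. For the measured compounds named here, no measured pair shows this change directly. Compound 3 carries the same entering group on a different core and does return a number, so for compound 4 a small step toward stronger inhibition is expected, an at least 1.5-fold lower number from compound 1 to compound 4 (0.17 log units; that floor lies within the scatter), though likely no larger than the usual scatter. Compound 4 is thus estimated at 20000 nM, between 5000 nM and 60000 nM.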

Compound 4, half-maximal inhibitory concentration: 4330 nM
Beside the measured number, compound 4's estimate is 4.6-fold (0.66 log units) above it; measured number outside the range, below it.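

In this assay, 1-methyl-1H-pyrazol-5-yl in place of phenyl on this aromatic carbon gives an at least 6.9-fold lower number from compound 1 to compound 4 (0.84 log units; beyond the scatter). For the compounds shown here, this is the first direct reading of the change, and it shows that the position responds to the swap, toward stronger inhibition. The true size of the step remains unknown because compound 1 sits at a limit: the limit of > 30000 nM in this assay, at which 1 of the 4 values shown sits.

The compounds shown leave open whether the methyl on the pyrazole matters, and whether a pyridine ring or an amine at this position would give stronger inhibition. They also leave open whether the same swap has a similar effect on other cores.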